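Swapping phenyl for pyridin-3-yl on a phosphate ester

A few compounds are considered here, and "the series" means these few. Any claim that something is new, unique, unknown or untested is made for them only; others in the source may bear on it.

Two nucleoside phosphate esters have been measured in a functional assay on T47D cells (Homo sapiens) for cytotoxicity, read by MTT assay, with a stated time of 48 h; on this read-out higher numbers stand for weaker inhibition and lower numbers for stronger inhibition. Compound 1 `O=C(O[C@H]1C[C@H](n2cc(F)c(=O)[nH]c2=O)O[C@@H]1COP(=O)(O)Oc1cccnc1)c1ccccc1` gives 14400 nM. Compound 2 `O=c1[nH]c(=O)n([C@H]2C[C@H](O)[C@@H](COP(=O)(O)Oc3ccccc3)O2)cc1F` gives 13400 nM, the lower of the two numbers, though the gap to compound 1 lies within the usual scatter. Compound 3 `O=c1[nH]c(=O)n([C@H]2C[C@H](O)[C@@H](COP(=O)(O)Oc3cccnc3)O2)cc1F` is not yet measured; it differs from compound 2 in one place: pyridin-3-yl in place of phenyl on an oxygen. Nothing measured here shows how this exchange alone shifts the numbers, so compound 3 is expected to sit close to compound 2, with a step of a 1.0-fold lower number from compound 2 to compound 3 (0.01 log units; within the scatter), none beyond the scatter. The estimate for compound 3 is 13000 nM, in the range 6000 nM to 28000 nM.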

Compound 3, half-maximal inhibitory concentration: 9350 nM
For compound 3 the middle estimate is 1.4-fold (0.14 log units) above the measured one, and the stated range covers the measured number.
By their numbers in this assay, from the lowest: compounds 3, 2 and 1 (each within the scatter of the next).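

In this assay, the direct exchange of phenyl for pyridin-3-yl on the oxygen bound to phosphorus gives a 1.4-fold lower number from compound 2 to compound 3 (0.16 log units; within the scatter), so this swap alone stays within the scatter. Replacing benzoyl with hydrogen on the oxygen on a saturated carbon gives a 1.5-fold lower number from compound 1 to compound 3 (0.19 log units; within the scatter), which also stays within the scatter, so neither change can be told apart from repeat variation. No supporting measurement bears on these small steps.

Still open, from the compounds shown here alone, is whether a naphthyl group or a longer alkyl chain on the phosphate oxygen would move the number beyond the scatter. The same question stands for an acetyl group in place of benzoyl.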